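A few compounds are considered here, and "the series" means these few. Any claim that something is new, unique, unknown or untested is made for them only; others in the source may bear on it.

Measured in a physicochemical assay, with a stated time of 6 min; on this read-out lower numbers stand for stronger inhibition and higher numbers for weaker inhibition:
- Compound 1 `O=C(Nc1ccc(F)cc1)Nc1nc(-c2cc3ccccc3o2)cs1`: 1130 nM
- Compound 2 `O=C(Nc1cccc([N+](=O)[O-])c1)Nc1nc(-c2cc3cc(Br)ccc3o2)cs1`: 159000 nM
- Compound 3 `COc1ccc(NC(=O)Nc2nc(-c3cc4cc(Br)ccc4o3)cs2)cc1`: > 200000 nM, a limit and not a number

Compound 3 gives only a limit and stands at the limit of > 200000 nM in this assay, at which 1 of the 3 values shown sits. Compound 4 `O=C(Nc1ccc(F)cc1)Nc1nc(-c2cc3cc(Br)ccc3o2)cs1` differs from it by one change, fluoro in place of methoxy on an aromatic carbon, para to a large group: fluoro in place of methoxy on an aromatic carbon. Among the compounds with values here, the one measured step that involves the leaving 4-methoxyphenyl is an at least 1.2-fold higher number from compound 2 to compound 3 (0.09 log units; that floor lies within the scatter). That step gives only a floor, so it sets no size for the change at hand. Compound 4 carries the same 4-fluorophenyl as compound 1, and compound 1 gives 1130 nM, but it is not a matched partner of compound 4, so it offers only a loose hint. A moderate move towards lower numbers in this assay is therefore expected, though the result may stay close to the limit. The expected change is an at least 3.3-fold lower number from compound 3 to compound 4 (0.52 log units; beyond the scatter). Compound 4 is estimated at 60000 nM, with an expected range of 5000 nM to 200000 nM.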

Compound 4, half-maximal inhibitory concentration: > 200000 nM
Compound 4: only a limit was reported (the forecaster's own chance of this, stated with the estimate: 25%); at least 3.3-fold (0.52 log units) between middle value and limit.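

In this assay compound 4 gives > 200000 nM, which is a limit and not a number, so fluoro in place of methoxy does not yield a readable value with the bromo present, and the step between compound 3 and compound 4 cannot be read: the limit of > 200000 nM in this assay, at which 2 of the 4 values shown sit. The new compound also isolates bromo in place of hydrogen on an aromatic carbon, a change that gives an at least 170-fold higher number from compound 1 to compound 4 (2.24 log units; beyond the scatter). The change of 4-fluorophenyl in place of 3-nitrophenyl gives an at least 1.2-fold higher number from compound 2 to compound 4 (0.09 log units; that floor lies within the scatter), which sets no size for that change.

The compounds shown leave open whether any group at this place gives a readable value while the bromo remains, for instance an amine or a carboxylic acid. They also leave open how methoxy at this place would read on the core of compound 1.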